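Cytotoxicity Tolerance Across Amide Side-Chain Variants

The source may report more compounds than this note shows. Statements on the series, on what has been measured and on what is new or still open speak of the compounds shown alone.

compound 1 `Cc1nc2cc(C(=O)NCc3ccc(F)c(C4CC4)c3)nn2c(-c2cc(F)c3c(c2C)CCCO3)c1[C@H](OC(C)(C)C)C(=O)O`: > 40000 nM
compound 2 `Cc1nc2cc(C(=O)NCCC3CCCCC3)nn2c(-c2cc(F)c3c(c2C)CCCO3)c1[C@H](OC(C)(C)C)C(=O)O`: > 40000 nM

In an ADME assay on MT2 cells (Homo sapiens) for cytotoxicity (a lower number here means that less compound is tolerated, a higher number that more compound is tolerated), compound 1 gives > 40000 nM, which is a limit of the assay. Compound 2 gives > 40000 nM, also a limit. The step that the two limits leave unreadable from compound 1 to compound 2 is therefore unreadable in size. Compound 2 thus stands at the limit, as shown by the limit of > 40000 nM in this assay, at which 2 of the 2 values shown sit. Compound 3 `Cc1nc2cc(C(=O)NCC3CCOCC3)nn2c(-c2cc(F)c3c(c2C)CCCO3)c1[C@H](OC(C)(C)C)C(=O)O` carries the change (oxan-4-yl in place of cyclohexylmethyl on a saturated chain carbon bound to an amide-type nitrogen). No readable measured step bears on this change, so no shift beyond the scatter is expected. Compound 3 is expected to show a step that the limit leaves unreadable from compound 2 to compound 3 and an estimated value of 45000 nM, ranging from 20000 nM to 100000 nM, most likely again only a limit.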

Compound 3, half-maximal cytotoxic concentration: > 40000 nM
Compound 3 ended at the assay's limit; the forecaster's own chance of this, stated with the estimate: 85%; the middle value lies beyond the limit too.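

Compound 3, like compound 1 and compound 2, sits at a limit in this assay, so no step among these compounds can be read: the limit of > 40000 nM in this assay, at which 3 of the 3 values shown sit. The compounds shown leave open whether these amide side chains differ in tolerance at all.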